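The source may hold more compounds than are shown below. What is called first, only, known or untested is meant among the compounds shown, and "the series" means these compounds.

Measured so far in a functional assay on CCRF-CEM cells (Homo sapiens) for antiproliferative activity, with a stated time of 72 h; a higher number here means a weaker inhibitor, a lower number a stronger inhibitor
Compound 1 `OC[C@H]1O[C@@H](n2cnc3c(NCc4ccccc4Cl)ncnc32)[C@H](O)[C@@H]1O` gives 14500 nM
Compound 2 `OC[C@H]1O[C@@H](n2cnc3c(NCc4ccc(Cl)cc4)ncnc32)[C@H](O)[C@@H]1O` gives 10200 nM
Compound 3 `OC[C@H]1O[C@@H](n2cnc3c(NCc4ccc(Br)cc4)ncnc32)[C@H](O)[C@@H]1O` gives 20600 nM

Two steps place compound 3 among these numbers: a 2.0-fold higher number from compound 2 to compound 3 (0.31 log units; beyond the scatter) and a 1.4-fold higher number from compound 1 to compound 3 (0.15 log units; within the scatter) (the first beyond the scatter, the second within it). Compound 4 `COc1cccc(CNc2ncnc3c2ncn3[C@@H]2O[C@H](CO)[C@@H](O)[C@H]2O)c1` carries 3-methoxyphenyl in place of 4-bromophenyl on a saturated chain carbon bound to a nitrogen on an aromatic ring. The remaining step bearing on this change is small: a 1.4-fold lower number from compound 1 to compound 2 (0.15 log units; within the scatter) for the two chlorophenyl compounds. Within the data shown here, no measured compound carries a methoxy group, so this evidence is indirect. The size of these steps leads to an expectation of no step beyond the scatter in this assay. The estimated step is small (a 1.3-fold lower number from compound 3 to compound 4 (0.11 log units; within the scatter)). For compound 4 the estimated value is 16000 nM (expected range 6500 nM to 40000 nM).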

Compound 4, half-maximal inhibitory concentration: 7600 nM
The estimate for compound 4 lay 2.1-fold (0.32 log units) above the measured number, and the stated range covers the measured number.
By their numbers in this assay, from the lowest: compounds 4, 2, 1 and 3 (each within the scatter of the next, the first and the last beyond it).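

In this assay, among these compounds, the 3-methoxyphenyl group is the only group here with a hydrogen-bond acceptor, and the position accepts it with a 2.7-fold lower number from compound 3 to compound 4 (0.43 log units; beyond the scatter). Against the chlorophenyl compounds, the change gives only a 1.3-fold lower number from compound 2 to compound 4 (0.13 log units; within the scatter) and a 1.9-fold lower number from compound 1 to compound 4 (0.28 log units; within the scatter), so the step beyond the scatter is confined to the 4-bromophenyl comparison. Nothing available here explains this difference.

The change alters both the substituent and its place on the ring, and these two effects cannot be separated here. As far as these compounds go, how an amine or a carboxylic acid on the ring, or a longer chain to it, would read in this assay also remains open.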